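A Dichlorophenyl Replaced by Methoxyphenyl on the Piperazine Nitrogen

This account rests on a few compounds, and the source may have more. Where it says the series, first, only, none or still open, it means among the compounds named here.

Of the compounds shown here, two sharing one core have been measured in a functional assay on the whole organism for inhibition, with Mus musculus as the target, at a dose of 25 mg/kg by the oral route; a higher number here means more inhibition at the dose given (going by the name of the read-out), a lower number less inhibition. Compound 1 `Clc1ccc(N2CCN(CCCOc3ccc4c(c3)CCC4)CC2)cc1` gives 43% there, while compound 2 `Clc1cc(Cl)cc(N2CCN(CCCOc3ccc4c(c3)CCC4)CC2)c1` gives 0%, so compound 2 stands lowest of the two numbers, with compound 1 the nearest. Within the data shown here, the single measured step is a number 43 percentage points lower from compound 1 to compound 2 (beyond the scatter), showing that the ring attached to the amine nitrogen in the ring matters greatly for this read-out.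

Compound 3 `COc1ccc(N2CCN(CCCOc3ccc4c(c3)CCC4)CC2)cc1` is the next compound to be examined. The change from compound 2 is 4-methoxyphenyl in place of 3,5-dichlorophenyl on an amine nitrogen in a ring. Among the measured compounds shown here, the only step that bears on it is the one from compound 1 to compound 2, which was large and downward; compound 3 carries a ring with a single group at the same place as in compound 1, but the methoxy group itself has no measured precedent here. Compound 3 is therefore expected to recover much of that loss, with a step of a number 35 percentage points higher from compound 2 to compound 3 (beyond the scatter). The estimate for compound 3 is 35%, within a range from 5% to 65%.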

Compound 3, a percentage reported as inhibition, in the whole organism at one dose (the size of the read-out at that dose, not a potency): 60%
Compound 3: the middle estimate sits 25 percentage points below what was measured; low and high end bracket the measured number.
By their numbers in this assay, from the lowest: compound 2; then compound 1; then compound 3.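

In this assay, 4-methoxyphenyl in place of 3,5-dichlorophenyl on the amine nitrogen in the ring gives a number 60 percentage points higher from compound 2 to compound 3 (beyond the scatter), so the earlier loss at this place does not extend to every substituted phenyl group. Methoxy in place of chloro on an aromatic carbon gives a smaller step, a number 17 percentage points higher from compound 1 to compound 3 (beyond the scatter), which shows that the identity of the group on the phenyl ring also changes the read-out, and not only how many groups it carries. Nothing available here explains either step.

As far as these compounds go, whether the low number of compound 2 comes from having two chlorines or from where they sit stays open, and a 3,5-dimethoxyphenyl group would bear on that question. How a plain phenyl group or a 4-hydroxyphenyl group behaves at this place is also unknown.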